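Working notes on compounds 1 to 4

The source may report more compounds than this note shows. Statements on the series, on what has been measured and on what is new or still open speak of the compounds shown alone.

Measured in a functional assay on ME-180 cells (Homo sapiens) for cytotoxicity, read by MTT assay, with a stated time of 72 h; a lower number here means a stronger inhibitor, a higher number a weaker inhibitor:
compound 1 `COc1ccc(/C=C/C(=O)Nc2cc(C(=O)c3cc(OC)c(OC)c(OC)c3)cc(OC)c2OC)cc1`: 12500 nM
compound 2 `COc1cccc(/C=C/C(=O)Nc2cc(C(=O)c3cc(OC)c(OC)c(OC)c3)cc(OC)c2OC)c1`: 8600 nM
compound 3 `COc1ccc(/C=C/C(=O)Nc2cc(C(=O)c3cc(OC)c(OC)c(OC)c3)cc(OC)c2OC)cc1N`: 13900 nM

Compound 3 carries the highest of the three numbers, but its gaps to the others, a 1.1-fold higher number from compound 1 to compound 3 (0.05 log units; within the scatter) and a 1.6-fold higher number from compound 2 to compound 3 (0.21 log units; within the scatter), both fall within the scatter, so the three compounds sit together in this assay. Compound 4 `C#CCOc1cccc(/C=C/C(=O)Nc2cc(C(=O)c3cc(OC)c(OC)c(OC)c3)cc(OC)c2OC)c1` differs from compound 3 by 3-(propargyloxy)phenyl in place of 3-amino-4-methoxyphenyl on a double-bonded chain carbon bound to a double-bonded chain carbon. For the measured compounds named here, two measured steps bear on this change: a 1.5-fold lower number from compound 1 to compound 2 (0.16 log units; within the scatter), and a 1.6-fold higher number from compound 2 to compound 3 (0.21 log units; within the scatter). Neither left the scatter, and nothing measured covers the propargyloxy group itself. Compound 4 is therefore expected to stay within the scatter of compound 3, a 1.5-fold lower number from compound 3 to compound 4 (0.17 log units; within the scatter). Compound 4 is estimated at 9500 nM, with a range from 4000 nM to 22000 nM.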

Compound 4, half-maximal inhibitory concentration: 8400 nM
The estimate for compound 4 lay 1.1-fold (0.05 log units) above the measured number; low and high end bracket the measured number.
By their numbers in this assay, from the lowest: compounds 4, 2, 1 and 3 (each within the scatter of the next).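

In this assay the ethynyl added on a saturated chain carbon bound to an oxygen on an aromatic ring moves nothing beyond the scatter (a 1.0-fold lower number from compound 2 to compound 4 (0.01 log units; within the scatter)). Replacing 3-amino-4-methoxyphenyl (a 1.7-fold lower number from compound 3 to compound 4 (0.22 log units; within the scatter)) or 4-methoxyphenyl (a 1.5-fold lower number from compound 1 to compound 4 (0.17 log units; within the scatter)) with 3-(propargyloxy)phenyl also stays within it, so a triple bond at this place leaves the series level. No available data explain this flat result.

Going by these compounds, whether a carboxylic acid or a longer chain on that oxygen would leave the scatter stays open. So does whether the same level holds on any other core or in any other cell line.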